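Capping a Phenol: From Compound 1 to Compound 3

This account rests on a few compounds, and the source may have more. Where it says the series, first, only, none or still open, it means among the compounds named here.

Two compounds have been measured so far in a functional assay on KM12 cells (Homo sapiens) for inhibition, read by sulforhodamine B assay, with a stated time of 48 h, tested at 0.1 uM; a lower number here means a stronger effect, a higher number a weaker effect of the compound at the concentration tested:

Compound 1 `O=C(Nc1cccc(-n2cc(-c3ccncc3)c(-c3cc(O)cc(Cl)c3)n2)c1)Nc1ccc(Cl)c(C(F)(F)F)c1` gives 92%
Compound 2 `O=C(Nc1cccc(-n2cc(-c3ccncc3)c(-c3cc(O)cc(Cl)c3)n2)c1)Nc1ccc(Cl)c(Cl)c1` gives 100%

Within the data shown here, compound 1 holds the lowest of these two numbers, but its only neighbour, compound 2, sits close by: the step of a number 8 percentage points higher from compound 1 to compound 2 (within the scatter) is within the scatter, so the two cannot be ranked against each other.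

The next compound, compound 3 `COc1cc(Cl)cc(-c2nn(-c3cccc(NC(=O)Nc4ccc(Cl)c(C(F)(F)F)c4)c3)cc2-c2ccncc2)c1`, carries a change of a different kind: methyl in place of hydrogen on an oxygen on an aromatic ring. Among the measured compounds shown here, neither of the measured compounds shows this change, so no measured step bears on it directly. For the measured compounds named here, the one measured step, a number 8 percentage points higher from compound 1 to compound 2 (within the scatter), concerns the urea end of the molecule and was itself within the scatter, which at least shows that small changes elsewhere have not moved the number much.

Going by the values given here, with no direct precedent, the expectation for compound 3 is a step of about a number 3 percentage points higher from compound 1 to compound 3 (within the scatter), that is, no change beyond the scatter. Compound 3 is therefore estimated at 95%, with a likely range from 80% to 106%.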

Compound 3, a percentage reported as activity, at one concentration (the size of the read-out at that concentration, not a potency): 98%
For compound 3 the middle estimate is 3 percentage points below the measured one, and the stated range covers the measured number.
By their numbers in this assay, from the lowest: compounds 1, 3 and 2 (each within the scatter of the next).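

Capping the phenol gives the first reading at this part of the molecule: in this assay, going from hydroxy to methoxy is a number 6 percentage points higher from compound 1 to compound 3 (within the scatter). The earlier pair differed only at the urea end, so this step adds that, at the single concentration tested, the hydrogen on this oxygen can be replaced by methyl without moving the number beyond the scatter. No measurement at hand speaks to why the number responds in this way.

Going by these compounds, what stays open is whether something other than methyl at this position, such as a longer chain on the oxygen or an amine in place of the hydroxy, would shift the number beyond the scatter, and a group that did so would show whether this position matters in this assay at all. Also open, on these data alone, is whether methoxy would read the same when combined with the chloro that stands in place of trifluoromethyl in compound 2, since the two changes appear here only one at a time.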